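Pyridin-4-yl in place of the dimethylaminophenyl group

The compounds below may be only part of what the source reports. "The series", "measured", "known", "first", "only" and "open" are said of these compounds alone.

Among the measured compounds shown here, compound 1 `CN(C)c1ccc(N2C(=O)NC3(CSC4=C3C(=O)c3ncccc3C4=O)C2=O)cc1` gives 90 nM in a functional assay on ACHN cells (Homo sapiens) for antiproliferative activity, read by MTT assay, with a stated time of 96 h (on this read-out lower numbers stand for stronger inhibition and higher numbers for weaker inhibition), the lowest of the three numbers measured so far. Compound 2 `O=C1NNC(=O)C2(CSC3=C2C(=O)c2ncccc2C3=O)N1` gives 1050 nM in this assay, and compound 3 `O=C1NN(c2ccc(Cl)cc2)C(=O)C2(CSC3=C2C(=O)c2ncccc2C3=O)N1` gives 360 nM in this assay, so compound 1 stands clearly ahead of both. Compound 4 `O=C1C2=C(C(=O)c3ncccc31)C1(CS2)NC(=O)N(c2ccncc2)C1=O` carries pyridin-4-yl in place of 4-(dimethylamino)phenyl on an amide-type nitrogen in a ring. For the measured compounds named here, the one measured step, a 2.9-fold lower number from compound 2 to compound 3 (0.46 log units; beyond the scatter), shows that an aryl group on this ring nitrogen lowers the number against hydrogen, but no measured pair compares one aryl with another, so it bears only indirectly here. A small step is therefore expected in this assay, probably toward a somewhat higher number. Compound 4 is estimated at 160 nM, within 60 nM to 450 nM. The expected step is a 1.8-fold higher number from compound 1 to compound 4 (0.25 log units; within the scatter).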

Compound 4, half-maximal inhibitory concentration: 80 nM
The estimate for compound 4 lay 2.0-fold (0.30 log units) above the measured number, within the range that was stated.
By their numbers in this assay, from the lowest: compounds 4 and 1 (each within the scatter of the next); then compound 3; then compound 2.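

In this assay, pyridin-4-yl in place of 4-(dimethylamino)phenyl on the amide-type nitrogen gives a 1.1-fold lower number from compound 1 to compound 4 (0.05 log units; within the scatter). Among the compounds shown here, this is the first direct comparison of two aromatic rings at this position, and the two groups cannot be told apart here, although they differ in size and ring type. No measurement shown explains this result.

Still open, on these data alone, is whether the position also accepts a saturated ring such as piperidine or a plain methyl group. Hydrogen on this nitrogen of the core of compound 1 also remains open.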